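Three measured amides and one still to come

A few compounds are considered here, and "the series" means these few. Any claim that something is new, unique, unknown or untested is made for them only; others in the source may bear on it.

Compound 1 `O=C(c1cncc(N2CC3CC(C2)N3)c1)N1CCCc2ccccc21` gives 0.196 nM in an assay on membranes from Cerebral cortex for displacement of a labelled ligand from Neuronal acetylcholine receptor; alpha4/beta2 (Rattus norvegicus); on this read-out higher numbers stand for weaker inhibition and lower numbers for stronger inhibition.
Compound 2 `O=C(c1cncc(N2CC3CC(C2)N3)c1)N1CCc2ccccc2C1` gives 0.031 nM in this assay.
Compound 3 `O=C(Nc1ccc(F)cc1)c1cncc(N2CC3CC(C2)N3)c1` gives 0.01 nM in this assay.

Compound 3 stands lowest of the three numbers in this assay, which here means the strongest inhibition. Its nearest neighbour is compound 2, whose number is higher by a margin beyond the usual scatter, and compound 1 lies further off still. Within this small set, then, the anilide of compound 3 sits clearly ahead of the two cyclic amides.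

The next compound, compound 4 `COc1cccc(NC(=O)c2cncc(N3CC4CC(C3)N4)c2)c1`, keeps the shared core and the amide but changes the aromatic group on the amide nitrogen: 3-methoxyphenyl in place of 4-fluorophenyl on an amide-type nitrogen. Among the compounds with values here, no pair of measured compounds shows this kind of exchange, so there is no measured step to lean on. Since compound 3 already gives 0.01 nM and the change touches only the substituent of the ring on the amide nitrogen, the step from compound 3 to compound 4 in this assay is expected to be small, most likely within the scatter, with any drift more likely toward a slightly higher number than a lower one: a 2.0-fold higher number from compound 3 to compound 4 (0.30 log units; within the scatter). Compound 4 is therefore expected to give about 0.02 nM, within a range of 0.005 nM to 0.08 nM.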

Compound 4, inhibition constant: 0.56 nM
Beside the measured number, compound 4's estimate is 28-fold (1.45 log units) below it; measured number above the stated range.
By their numbers in this assay, from the lowest: compound 3; then compound 2; then compound 1; then compound 4.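

Placing 3-methoxyphenyl in place of 4-fluorophenyl on an amide-type nitrogen gives a 56-fold higher number from compound 3 to compound 4 (1.75 log units; beyond the scatter) in this assay, so the aromatic group at this position has a large bearing on the number, which the earlier compounds, with no step between them, could not show. The change also qualifies the lead that the anilide compound 3 held over the two cyclic amides: that lead does not extend to every anilide, since compound 4 at 0.56 nM stands above compound 1 at 0.196 nM and is the highest of the four numbers. Nothing in the available data accounts for the size of this step.

How a 3-fluorophenyl or a 4-methoxyphenyl group would read on this nitrogen remains open, so the compounds shown cannot separate the exchange of substituent from the change in its place on the ring. Also open, as far as these compounds go, is how an unsubstituted phenyl or a pyridyl ring at the same position would stand in this assay.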